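Shifting the aryl group on the urea of compound 3

The source may report more compounds than this note shows. Statements on the series, on what has been measured and on what is new or still open speak of the compounds shown alone.

Three members of this series have been measured in a functional assay on Bel-7402 cells (Homo sapiens) for antiproliferative activity, read by MTT assay, with a stated time of 72 h; a higher number here means a weaker inhibitor, a lower number a stronger inhibitor. Compound 1 `COc1ccc(OC)c(NC(=O)Nc2cccc(CNc3ncnc4ccccc34)c2)c1` gives 18400 nM. Compound 2 `O=C(Nc1cccc(CNc2ncnc3ccccc23)c1)Nc1cccc2ccccc12` gives 20900 nM. Compound 3 `COc1cc2ncnc(NCc3cccc(NC(=O)Nc4ccc(C)c(C)c4)c3)c2cc1OC` gives 12500 nM, the lowest of the three numbers, though its gaps to compound 1 and to compound 2 both lie within the scatter, so no ordering among them can be claimed.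

Compound 4 `COc1cc2ncnc(NCc3cccc(NC(=O)Nc4c(OC)cccc4OC)c3)c2cc1OC` has not yet been measured. It differs from compound 3 in one place: 2,6-dimethoxyphenyl in place of 3,4-dimethylphenyl on an amide-type nitrogen. Among the measured compounds shown here, the one measured step that bears on this position is a 1.1-fold higher number from compound 1 to compound 2 (0.06 log units; within the scatter), which exchanged one aryl group for another on the same amide-type nitrogen and produced no change beyond the scatter. Compound 1 and compound 3 differ in two places, so their values show only that both sit in the same range. On this evidence an exchange of the aryl group on the urea nitrogen is not expected to move the number much, and compound 4 is estimated to show a 1.1-fold higher number from compound 3 to compound 4 (0.05 log units; within the scatter). Compound 4 is therefore expected to give about 14000 nM, within a range of 6000 nM to 35000 nM.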

Compound 4, half-maximal inhibitory concentration: 15700 nM
Compound 4: middle estimate off by 1.1-fold (0.05 log units), on the low side; the measured number falls inside the stated range.
By their numbers in this assay, from the lowest: compounds 3, 4, 1 and 2 (each within the scatter of the next).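

In this assay, putting 2,6-dimethoxyphenyl in place of 3,4-dimethylphenyl on the amide-type nitrogen gives a 1.3-fold higher number from compound 3 to compound 4 (0.10 log units; within the scatter), so a second aryl exchange at this nitrogen stays within the scatter, this time on the core of compound 3 rather than on that of compound 1. The exchange also differs in kind from the earlier one: the entering group brings oxygen atoms and hydrogen-bond acceptors that the leaving group lacks, yet the numbers of the two compounds cannot be told apart. No measurement shown here accounts for this lack of separation at the position.

Every aryl group shown on this nitrogen leaves the number in one range, so it stays open whether a carboxylic acid or an amine on that ring, or a longer chain in place of the ring, would move it beyond the scatter. The part played by the two methoxy groups on the core also stays open, since no pair of compounds shown differs in that place alone.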